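Trifluoromethyl for Fluoro on an Inactive Amide Scaffold

The compounds below may be only part of what the source reports. "The series", "measured", "known", "first", "only" and "open" are said of these compounds alone.

Compound 1, `C/C(=C\c1cc(-c2ccc(F)cc2)cs1)C(N)=O`, was examined in a functional assay on A549 cells (Homo sapiens) for cytotoxicity, read by CCK-8 assay, with a stated time of 24 h; a lower number here means a stronger inhibitor, a higher number a weaker inhibitor. In this assay compound 1 gives > 50000 nM, which is a limit of the assay rather than a measured number. A second compound, compound 2, `C/C(=C\c1cccc(-c2ccccc2)c1)C(N)=O`, carries the same amide-bearing side chain on a different aromatic core. In this assay compound 2 gives > 50000 nM, again a limit and not a number. Both values shown therefore sit at the same ceiling, (the limit of > 50000 nM in this assay, at which 2 of the 2 values shown sit), so compound 1 stands at the edge of what the assay can report, with no measurable potency, and compound 2 shows nothing different.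

Compound 3, `C/C(=C\c1cc(-c2ccc(C(F)(F)F)cc2)cs1)C(N)=O`, differs from compound 1 by trifluoromethyl in place of fluoro on an aromatic carbon. For the measured compounds named here, no measured pair in this set follows such a change, so nothing here tells how large a step it should bring. Given that every value shown rests at the limit, the expected step is a step that the limit leaves unreadable from compound 1 to compound 3, in effect no change beyond the usual scatter. Compound 3 is accordingly expected to give about 60000 nM, within a range from 15000 nM to 200000 nM, and the assay would most likely again report only a limit.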

Compound 3, half-maximal inhibitory concentration: > 50000 nM
Compound 3 ended at the assay's limit (the forecaster's own chance of this, stated with the estimate: 80%); the middle value does not contradict the limit.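

In this assay, for the compounds shown here, compound 1 and compound 3 both rest at a limit rather than a number, so no step between them can be read, and trifluoromethyl in place of fluoro has no size here. All the compounds shown share one ceiling: the limit of > 50000 nM in this assay, at which 3 of the 3 values shown sit. They leave open whether any change to these structures would bring a measurable potency.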